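Swapping fluoro for methyl on an inactive aryl compound

The source may report more compounds than this note shows. Statements on the series, on what has been measured and on what is new or still open speak of the compounds shown alone.

Measured compounds, each value a limit and not a number:
- Compound 1 `CSc1nnc(-c2ccc(F)cc2)n1C` gives > 200 mg/kg as its limit
- Compound 2 `Cn1c(-c2cccs2)nnc1S(C)(=O)=O` gives > 200 mg/kg as its limit
- Compound 3 `Cn1c(-c2cccc3ccccc23)nnc1[S+](C)[O-]` gives > 200 mg/kg as its limit

All three results come from a functional assay on the whole organism for antagonist activity, with Mus musculus as the target (on this read-out higher numbers stand for an effect only at larger amounts of compound and lower numbers for an effect already at smaller amounts), and they tell one story (the limit of > 200 mg/kg in this assay, at which 3 of the 3 values shown sit). None of the three compounds therefore has an actual dose to compare, and no order among them can be drawn.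

Compound 1 stands at > 200 mg/kg in this assay, which is a limit and not a number.

Compound 4 `CSc1nnc(-c2ccc(C)cc2)n1C` differs from compound 1 in one place (methyl in place of fluoro on an aromatic carbon). This is methyl in place of fluoro on an aromatic carbon, on a six-membered aromatic ring of carbon only, para to a group of 8 heavy atoms.

Among the compounds with values here, no two measured compounds differ in just one place, so the data give no direct size for such a swap. A step beyond the usual scatter is not expected here, in either direction, and another limit is the likeliest outcome for compound 4. That expectation rests on compound 1 and its limit of > 200 mg/kg as the closest measured neighbour.

The expected step that the limit leaves unreadable from compound 1 to compound 4 is small. If a number is reported, the estimate for compound 4 is 250 mg/kg (expected range 100 mg/kg to 500 mg/kg).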

Compound 4, dose for half-maximal effect: > 100 mg/kg
Compound 4: no number, only a limit; the forecaster's own chance of this, stated with the estimate: 65%; the middle value lies beyond the limit too.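

In this assay compound 4 gives > 100 mg/kg, which is a limit and not a number. Compound 1 also has only a limit, so the step between compound 1 and compound 4 cannot be read. The compounds shown leave open whether methyl in place of fluoro changes the dose needed for an effect at all.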